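The source may report more compounds than this note shows. Statements on the series, on what has been measured and on what is new or still open speak of the compounds shown alone.

For the measured compounds named here, compound 2 `CN(C)CCCCOC(=O)Nc1ccc(Cn2nc(-c3cccc(F)c3)c3ccccc3c2=O)cc1` sits at the high end of the two numbers so far in an ADME assay on Huh-7 cells (Homo sapiens) for cytotoxicity, read by MTT assay, with a stated time of 48 h; a higher number here means that more compound is tolerated, a lower number that less compound is tolerated: compound 2 gives 37400 nM, and compound 1 `CN(C)CCCCOC(=O)Nc1ccc(Cn2nc(-c3ccc(C(F)(F)F)cc3)c3ccccc3c2=O)cc1` gives 3360 nM. Going by the values given here, the one step between them, an 11-fold higher number from compound 1 to compound 2 (1.05 log units; beyond the scatter), is the only measured step and it exchanges the whole aryl substituent, not a single group at a fixed position.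

Compound 3 `CN(C)CCCCOC(=O)Nc1ccc(Cn2nc(-c3cccc(C#N)c3)c3ccccc3c2=O)cc1` is the next member. It differs from compound 2 by cyano in place of fluoro on an aromatic carbon, the group sitting meta to a large group on the six-membered carbon ring.

Among the compounds with values here, no measured pair shows a cyano against a fluoro, so the step from compound 1 to compound 2 bears on this change only indirectly: it shows that the aryl substituent can move this assay by a large margin, but gives no direction for cyano in place of fluoro at the same position. A step in this assay within or near the scatter is therefore expected, with a slight lean toward a lower number, as a 1.5-fold lower number from compound 2 to compound 3 (0.17 log units; within the scatter). For compound 3 the estimate in this assay is 25000 nM, with a range from 8000 nM to 75000 nM.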

Compound 3, half-maximal cytotoxic concentration: 17200 nM
Beside the measured number, compound 3's estimate is 1.5-fold (0.16 log units) above it, and the stated range covers the measured number.
By their numbers in this assay, from the lowest: compound 1; then compound 3; then compound 2.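

In this assay, for the compounds shown here, the change of fluoro to cyano on an aromatic carbon, meta to a large group, gives a measured step at a fixed position for the first time (a 2.2-fold lower number from compound 2 to compound 3 (0.34 log units; beyond the scatter)), showing that this single exchange moves the number modestly downward, with its size printed as beyond the scatter. Compound 3 still stands above compound 1 (a 5.1-fold higher number from compound 1 to compound 3 (0.71 log units; beyond the scatter)), so among the three compounds both 3-substituted phenyl groups are tolerated at higher concentrations than 4-(trifluoromethyl)phenyl, although that step changes both the group and its place on the ring. Nothing measured here accounts for the direction or size of these steps.

The comparison of compound 1 with the other two leaves open whether the lower number follows trifluoromethyl itself or its place on the ring, a question that 3-(trifluoromethyl)phenyl and 4-cyanophenyl would separate. On these data alone, it also remains open how an amine, a carboxylic acid or a methoxy group at the same position would fall relative to fluoro and cyano, and whether the steps seen here would hold with a longer chain in place of the present one.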